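The compounds below may be only part of what the source reports. "The series", "measured", "known", "first", "only" and "open" are said of these compounds alone.

Within the data shown here, in a functional assay on HepG2 cells (Homo sapiens) for antiproliferative activity, read by fluorescence and resazurin assay, with a stated time of 48 h (a lower number here means a stronger inhibitor, a higher number a weaker inhibitor), compound 2 `O=C(N/N=C/c1cccnc1)c1cc2cc(Br)ccc2oc1=O` gives 19000 nM, the highest of the three numbers measured so far. Compound 3 `CCOc1ccc2nc(Cl)c(/C=N/NC(=O)c3cc4cc([N+](=O)[O-])ccc4oc3=O)cc2c1` gives 18100 nM, which lies within the scatter of compound 2, while compound 1 `O=C(N/N=C/c1ccncc1)c1cc2cc(Br)ccc2oc1=O` gives 4890 nM, and the step of a 3.9-fold higher number from compound 1 to compound 2 (0.59 log units; beyond the scatter) is modest but beyond the scatter. Compound 4 `O=C(N/N=C/c1cccnc1)c1cc2ccccc2oc1=O` differs from compound 2 by hydrogen in place of bromo on an aromatic carbon. Among the measured compounds shown here, no measured step involves this change: the one measured step alters a different group, so it offers no guide to direction or size here. With the rest of compound 2 unchanged, the account expects a step of about a 1.3-fold higher number from compound 2 to compound 4 (0.12 log units; within the scatter), without a confident direction. Compound 4 is therefore estimated at 25000 nM, in the range 8000 nM to 80000 nM.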

Compound 4, half-maximal inhibitory concentration: 15900 nM
Beside the measured number, compound 4's estimate is 1.6-fold (0.20 log units) above it; measured number inside the range.
By their numbers in this assay, from the lowest: compound 1; then compounds 4, 3 and 2 (each within the scatter of the next).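

In this assay, hydrogen in place of bromo on this aromatic carbon gives a 1.2-fold lower number from compound 2 to compound 4 (0.08 log units; within the scatter) and so stays within the scatter. Among these compounds, this is the first reading at this position, as the earlier step changed only the pyridine attachment, and here the bromo group can go without a change beyond the scatter, at least with pyridin-3-yl in place. No evidence at hand bears on this result. The compounds shown leave open whether the same replacement would hold with the pyridin-4-yl of compound 1, and whether an amine or a carboxylic acid on this carbon would shift the number beyond the scatter.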